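A few compounds are considered here, and "the series" means these few. Any claim that something is new, unique, unknown or untested is made for them only; others in the source may bear on it.

Three compounds built on one shared core differ only in the group attached to an aromatic ring. In an assay on HEK293 cells for inhibition of Voltage-dependent T-type calcium channel subunit alpha-1G (Homo sapiens), read by fluorescence, tested at 10 uM (a lower number here means less inhibition, a higher number more inhibition at the concentration tested (going by the name of the read-out)), compound 1 `CCCc1nc(-c2ccccc2)c(CNCCCN2CCN(c3ccccc3)CC2)o1` gives 43.7%. Going by the values given here, compound 2 `CCCc1nc(-c2ccccc2)c(CNCCCN2CCN(c3cccc(OC)c3)CC2)o1` gives 36.4%, and compound 3 `CCCc1nc(-c2ccccc2)c(CNCCCN2CCN(c3ccc(C(F)(F)F)cc3)CC2)o1` gives 51.6%, the highest of the three numbers, although the step of a number 7.9 percentage points higher from compound 1 to compound 3 (within the scatter) lies within the scatter; only the step of a number 15.2 percentage points higher from compound 2 to compound 3 (beyond the scatter) reaches beyond it. Compound 4 `CCCc1nc(-c2ccccc2)c(CNCCCN2CCN(c3ccc(C)cc3)CC2)o1` carries a single change from compound 3: methyl in place of trifluoromethyl on an aromatic carbon. Among the compounds with values here, no measured step covers methyl itself; the closest guide is the trifluoromethyl-for-hydrogen step, which was small. A small downward shift, within the scatter, is therefore expected, a number 7.6 percentage points lower from compound 3 to compound 4 (within the scatter). Compound 4 is estimated at 44%, with a range from 30% to 58%.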

Compound 4, a percentage reported as inhibition, at one concentration (the size of the read-out at that concentration, not a potency): 53.9%
The estimate for compound 4 lay 9.9 percentage points below the measured number; low and high end bracket the measured number.
By their numbers in this assay, from the lowest: compounds 2, 1, 3 and 4 (each within the scatter of the next, the first and the last beyond it).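

Replacing trifluoromethyl with methyl at this place, para to a large group, leaves the result in this assay unresolved (a number 2.3 percentage points higher from compound 3 to compound 4 (within the scatter)), so the two groups cannot be told apart here. Methyl in place of hydrogen clears the scatter (a number 10.2 percentage points higher from compound 1 to compound 4 (beyond the scatter)), which the trifluoromethyl step did not, and 4-methylphenyl also clears it against 3-methoxyphenyl (a number 17.5 percentage points higher from compound 2 to compound 4 (beyond the scatter)). No available evidence explains these results.

On these data alone, whether a chlorine atom, an amine or an ethyl group at this place would match methyl remains open. So does the result with methyl elsewhere on this ring.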